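Swapping the halophenyl ring on the ether oxygen of compound 1

The compounds below may be only part of what the source reports. "The series", "measured", "known", "first", "only" and "open" are said of these compounds alone.

Compound 1 `O=c1c2ccccc2nc(-c2ccccc2)n1/N=C/c1ccc(Oc2ccc(Br)cc2)cc1` is the most lipophilic of the three measured compounds. In a physicochemical assay for lipophilicity, in phosphate buffer, measured as octanol-water partition (a higher number here means a more lipophilic compound, a lower number a more polar compound), compound 1 gives 6.39. Its nearest neighbour is compound 2 `CCCc1nc2ccccc2c(=O)n1/N=C/c1ccc(Oc2ccc(Br)cc2)cc1`, which in this assay gives 5.88; the furthest is compound 3 `CCCc1nc2ccccc2c(=O)n1/N=C1/C(=O)Nc2ccccc21`, which in this assay gives 3.23.

The new compound, compound 4 `Cc1cc(Oc2ccc(/C=N/n3c(-c4ccccc4)nc4ccccc4c3=O)cc2)ccc1Cl`, keeps the whole core of compound 1 and alters only the ring on the ether oxygen: 4-chloro-3-methylphenyl in place of 4-bromophenyl on an oxygen on an aromatic ring.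

For the measured compounds named here, only one single-place step among the measured compounds exists, and it lies elsewhere in the molecule: a number 0.51 log units lower from compound 1 to compound 2 (beyond the scatter). It describes the carbon of the core, not the phenoxy ring, so it offers no direct guide to the present change. The pair of compound 2 and compound 3 differs in far more than one place and is no guide either. The expectation for compound 4 therefore rests mainly on the value of compound 1 and on the fact that the departing and entering groups are both single aromatic rings with neither donors nor acceptors, the entering one carrying one more heavy atom.

On that basis compound 4 is expected to land close to compound 1, with at most a small rise, a number 0.31 log units higher from compound 1 to compound 4 (beyond the scatter), giving an estimate of 6.7 in this assay, within a range from 6.3 to 7.1.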

Compound 4, partition coefficient: 6.52
Compound 4: middle estimate off by 0.18 log units, on the high side, and the stated range covers the measured number.
By their numbers in this assay, from the lowest: compound 3; then compound 2; then compounds 1 and 4 (each within the scatter of the next).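

In this assay, the exchange gives a number 0.13 log units higher from compound 1 to compound 4 (within the scatter), the first step among these compounds that touches the ring on the ether oxygen rather than the carbon of the core. For the compounds shown here, at this position, then, 4-chloro-3-methylphenyl with its 8 heavy atoms and 4-bromophenyl with its 7 cannot be told apart in this read-out, whereas the only earlier single-place step, a number 0.51 log units lower from compound 1 to compound 2 (beyond the scatter), at the other place in the molecule, lies beyond the scatter. Nothing measured here accounts for this result.

The compounds shown leave open whether a ring on this oxygen bearing an amine or a carboxylic acid, or a longer chain in place of the ring, would give a number beyond the scatter of compound 1. They also leave open whether the same exchange of 4-bromophenoxy to 4-chloro-3-methylphenoxy would read alike on compound 2, which carries propyl in place of phenyl on the core.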